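From 3-chloro-5-fluorophenyl to 2-chloropyridin-3-yl

This account rests on a few compounds, and the source may have more. Where it says the series, first, only, none or still open, it means among the compounds named here.

- Compound 1 `CCN(CC)c1ccc(NC(=O)c2cc(Cl)ccc2O)c(Cl)c1` gives 55500 nM
- Compound 2 `O=C(Nc1ccc(NCc2ccc(Cl)cc2)cc1Cl)c1cc(Cl)ccc1O` gives 59700 nM
- Compound 3 `O=C(Nc1ccc(NCc2cc(F)cc(Cl)c2)cc1Cl)c1cc(Cl)ccc1O` gives 11100 nM

These values come from an ADME assay on A549 cells (Homo sapiens) for cytotoxicity, read by resazurin assay, with a stated time of 48 h (on this read-out lower numbers stand for higher toxicity in this test and higher numbers for lower toxicity in this test), and describe how much of each compound it takes to harm the cells. Compound 3 stands lowest of the three at 11100 nM and is thus the most toxic so far.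

Compound 4 `O=C(Nc1ccc(NCc2cccnc2Cl)cc1Cl)c1cc(Cl)ccc1O` differs from compound 3 in one place only (2-chloropyridin-3-yl in place of 3-chloro-5-fluorophenyl on a saturated chain carbon bound to a nitrogen on an aromatic ring). It carries 2-chloropyridin-3-yl in place of 3-chloro-5-fluorophenyl on a saturated chain carbon bound to a nitrogen on an aromatic ring.

The most relevant measurement is a 5.4-fold lower number from compound 2 to compound 3 (0.73 log units; beyond the scatter) at this same place, which shows that a swap here can move the number beyond the scatter. The other, a 1.1-fold higher number from compound 1 to compound 2 (0.03 log units; within the scatter) for a different swap, stays within the scatter. Among the compounds with values here, no measured compound carries 2-chloropyridin-3-yl, so any forecast remains loose.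

Compound 3 is one low value against two higher ones, so a partial move back upward is expected, smaller than the drop seen from compound 2. The estimated change is a 2.5-fold higher number from compound 3 to compound 4 (0.40 log units; beyond the scatter) and would mean lower toxicity. For compound 4 the estimated value is 28000 nM within an expected range of 9000 nM to 70000 nM in this assay when measured.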

Compound 4, half-maximal cytotoxic concentration: 101000 nM
Compound 4: the middle estimate sits 3.6-fold (0.56 log units) below what was measured; the measured number lies above the stated range.
By their numbers in this assay, from the lowest: compound 3; then compounds 1, 2 and 4 (each within the scatter of the next).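

In this assay this place, on a saturated chain carbon bound to a nitrogen on an aromatic ring, now moves the number in both directions, with a 5.4-fold lower number from compound 2 to compound 3 (0.73 log units; beyond the scatter) going down and a 9.1-fold higher number from compound 3 to compound 4 (0.96 log units; beyond the scatter) going up on the swap to 2-chloropyridin-3-yl. Two further comparisons, a 1.7-fold higher number from compound 2 to compound 4 (0.23 log units; within the scatter) and a 1.8-fold higher number from compound 1 to compound 4 (0.26 log units; within the scatter), place compound 4 level with compound 1 and compound 2, so the higher toxicity in this test is tied to the 3-chloro-5-fluorophenyl group of compound 3 and is not shared by the other three compounds. Nothing available explains why this group stands apart.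

The compounds shown do not separate the two halogens of compound 3, and a 3-fluorophenyl or a 3-chlorophenyl group at this place would show whether either one alone brings the number down. They also leave open what the chlorine of compound 4 contributes, which a plain pyridin-3-yl group at the same place would test.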